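The source may report more compounds than this note shows. Statements on the series, on what has been measured and on what is new or still open speak of the compounds shown alone.

Of the compounds shown here, three sharing one core have been measured in a functional assay on DLD-1 cells (Homo sapiens) for cytotoxicity, with a stated time of 48 h; on this read-out lower numbers stand for stronger inhibition and higher numbers for weaker inhibition. Compound 1 `CCCOc1ccc2oc(/C=C/[S+](C)[O-])cc(=O)c2c1` gives 6200 nM, compound 2 `Cc1ccc2oc(/C=C/[S+](C)[O-])cc(=O)c2c1` gives 7000 nM, and compound 3 `CCC(=O)Oc1ccc2oc(/C=C/[S+](C)[O-])cc(=O)c2c1` gives 9000 nM; compound 3 has the highest of the three numbers, yet all three sit within the scatter of one another. Compound 4 `CCCCCOc1ccc2oc(/C=C/[S+](C)[O-])cc(=O)c2c1` differs from compound 3 as follows: pentyl in place of propanoyl on an oxygen on an aromatic ring. Among the measured compounds shown here, the one measured step touching this position runs the other way, where propanoyl replaced propyl and gave a 1.5-fold higher number from compound 1 to compound 3 (0.16 log units; within the scatter), a change within the scatter. Reversing that direction with a longer chain is therefore expected to move the number little. For compound 4 the expected step is a 1.5-fold lower number from compound 3 to compound 4 (0.18 log units; within the scatter), and the estimate is 6000 nM, ranging from 3000 nM to 12000 nM.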

Compound 4, half-maximal inhibitory concentration: 6600 nM
Compound 4: the middle estimate sits 1.1-fold (0.04 log units) below what was measured; measured number inside the range.
By their numbers in this assay, from the lowest: compounds 1, 4, 2 and 3 (each within the scatter of the next).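

In this assay, pentyl on this oxygen stays within the scatter of propanoyl (a 1.4-fold lower number from compound 3 to compound 4 (0.13 log units; within the scatter)) and of propyl (a 1.1-fold higher number from compound 1 to compound 4 (0.03 log units; within the scatter)), and pentyloxy stays within the scatter of methyl on the aromatic carbon (a 1.1-fold lower number from compound 2 to compound 4 (0.03 log units; within the scatter)). Extending the propyl chain with ethyl therefore adds a longer chain to the comparison without separating any of the four compounds. No supporting evidence bears on this result. Still open, as far as these compounds go, is whether any group here can move the number beyond the scatter, such as a chain carrying an amine or a carboxylic acid.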